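A Chain Added to the Ether of Two Related Cores

The source may report more compounds than this note shows. Statements on the series, on what has been measured and on what is new or still open speak of the compounds shown alone.

Measured compounds:
compound 1 `COc1ccc(/C=C/C(=O)NNC(=O)c2ccncc2)cc1` gives 168000 nM in an ADME assay on THP-1 cells (Homo sapiens) for cytotoxicity, read by MTT assay, with a stated time of 72 h; a lower number here means a stronger inhibitor, a higher number a weaker inhibitor
compound 2 `CC(C)=CCC/C(C)=C/COc1ccc(/C=C/C(=O)NNC(=O)c2ccncc2)cc1` gives 43000 nM in this assay
compound 3 `COc1ccc(/C=C/C(=O)N/N=c2/[nH]ncc3ccccc23)cc1` gives 437000 nM in this assay

Compound 3 stands highest of the three measured numbers. Its nearest neighbour is compound 1, while compound 2 lies furthest from it. The difference between the core of compound 1 and the core of compound 3 is not broken down here.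

Within the first core, compound 2 differs from compound 1 by 2,6-dimethylhepta-1,5-dien-1-yl in place of hydrogen on a saturated chain carbon bound to an oxygen on an aromatic ring and gives a 3.9-fold lower number from compound 1 to compound 2 (0.59 log units; beyond the scatter). The unmeasured compound 4 `CC(C)=CCC/C(C)=C/COc1ccc(/C=C/C(=O)N/N=c2/[nH]ncc3ccccc23)cc1` carries the same change on the second core: compound 4 differs from compound 3 by 2,6-dimethylhepta-1,5-dien-1-yl in place of hydrogen on a saturated chain carbon bound to an oxygen on an aromatic ring. The place of the change reads the same for both pairs, so this is the same change made on a different core.

Compound 4 has not yet been measured in this assay. Because the step of a 3.9-fold lower number from compound 1 to compound 2 (0.59 log units; beyond the scatter) was beyond the scatter, a step of similar direction and size is expected when the same change is made on the second core, read as a 3.9-fold lower number from compound 3 to compound 4 (0.59 log units; beyond the scatter). This rests on one measured pair only, so the width of the expectation is kept broad. The estimate for compound 4 in this assay is 112000 nM, with a range from 45000 nM to 280000 nM.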

Compound 4, half-maximal inhibitory concentration: 56000 nM
Compound 4: middle estimate off by 2.0-fold (0.30 log units), on the high side; the measured number falls inside the stated range.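

In this assay the 3,7-dimethylocta-2,6-dien-1-yl ether that replaces the methoxy group lowers the number on the second core as well, with a 7.8-fold lower number from compound 3 to compound 4 (0.89 log units; beyond the scatter). Set beside the step on the first core, the change carries over in direction, and the two steps cannot be told apart in size: the same change on two cores in this assay, a 3.9-fold lower number (0.59 log units; beyond the scatter) from compound 1 to compound 2 and a 7.8-fold lower number (0.89 log units; beyond the scatter) from compound 3 to compound 4, 2.0-fold (0.30 log units) apart, within the scatter of two such steps. This rests on two cores only, so it shows that the change transferred within this pair of cores but not that it would do so on any other core or why the number falls, and the two compounds carrying the chain are not separated by the core difference, with a 1.3-fold higher number from compound 2 to compound 4 (0.11 log units; within the scatter).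

The compounds shown leave open how much of the step depends on this particular chain, since a shorter chain such as a 3-methylbut-2-en-1-yl group or the saturated 3,7-dimethyloctyl chain could show whether its length or its double bonds matter. They also leave open whether a chain ending in an amine or a carboxylic acid at the same place would give a step of similar direction and size on both cores.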